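This account rests on a few compounds, and the source may have more. Where it says the series, first, only, none or still open, it means among the compounds named here.

In an ADME assay (liver) for metabolic stability, with Liver microsome (Rattus norvegicus) as the target, read by LC-MS, using microsomes and NADPH, with stated times of 5 min and 60 min, tested at 4 uM (a higher number here means that more of the compound is left, a lower number that less of the compound is left), compound 1 (`Cc1c(OCCCCOc2cccc(C(=O)O)c2)ccc(C(=O)CC2CCCC2)c1O`) gives 55%, compound 2 (`Cc1c(OCCCCOc2cccc(C(=O)O)c2)ccc(C(=O)CC(C)C)c1O`) gives 51% and compound 3 (`COc1cc(C(=O)O)ccc1OCCCCOc1ccc(C(=O)CC(C)(C)C)c(O)c1C`) gives 49%, so compound 1 stands within the scatter of both others. Compound 4 (`Cc1cc(OCCCCOc2ccc(C(=O)CC3CCCC3)c(O)c2C)ccc1C(=O)O`) follows from compound 1 by one change: 4-carboxy-3-methylphenyl in place of 3-carboxyphenyl on an oxygen on a saturated carbon. Within the data shown here, no measured step covers this change. The only one available, a number 4 percentage points lower from compound 1 to compound 2 (within the scatter), lies within the scatter and concerns a different place, isopropyl in place of cyclopentyl. Compound 3 differs from compound 1 in more than one place and offers no clean comparison. A shift beyond the scatter is therefore not expected, and the expected change is a number 3 percentage points lower from compound 1 to compound 4 (within the scatter). For compound 4 the estimated value is 52%, with an expected range of 38% to 66%.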

Compound 4, percent of the compound remaining: 55%
For compound 4 the middle estimate is 3 percentage points below the measured one, and the stated range covers the measured number.
By their numbers in this assay, from the lowest: compounds 3, 2, 1 and 4 (each within the scatter of the next).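

In this assay, the swap to 4-carboxy-3-methylphenyl in place of 3-carboxyphenyl on an oxygen on a saturated carbon gives no change at the digits printed from compound 1 to compound 4 (within the scatter). Among these compounds, this is the first clean reading at this position: the earlier step concerned only the other end of the molecule, and here the added methyl on the carboxyphenyl group leaves the read-out within the scatter. No available evidence explains this result. Still open, as far as these compounds go, is whether an amide or a tetrazole in place of the carboxylic acid would read alike. Also open, from the compounds shown here alone, is whether the same swap gives the same result with isopropyl in place of cyclopentyl.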